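A few compounds are considered here, and "the series" means these few. Any claim that something is new, unique, unknown or untested is made for them only; others in the source may bear on it.

Compound 1 `Cc1cc(Cl)c2oc(N3CCN(C)CC3)nc2c1` gives 6.22 in a functional assay on ileum (strain Hartley) for agonist activity at 5-hydroxytryptamine receptor 3A (Cavia porcellus); on this read-out lower numbers stand for lower potency and higher numbers for higher potency (the scale is a negative logarithm). Compound 2 `CN1CCN(c2nc3cc(C(F)(F)F)ccc3o2)CC1` gives only a limit, not a number, in this assay: < 4. Compound 3 `COc1cccc2nc(N3CCN(C)CC3)oc12` likewise gives only a limit in this assay: < 4.

Compound 2 therefore stands at the floor of what this assay can report, and (the limit of < 4 in this assay, at which 2 of the 3 values shown sit). Compound 4 `CN1CCN(c2nc3cc(Br)ccc3o2)CC1` has not yet been measured; set beside compound 2 it carries bromo in place of trifluoromethyl on an aromatic carbon. Within the data shown here, no measured pair differs in exactly this way, so the size of the step is open. Compound 1, which also carries a halogen on its core, does reach a measurable value, which leaves room for a modest gain. A step of a number at least 0.80 log units higher from compound 2 to compound 4 (beyond the scatter) is expected. Compound 4 is estimated at 4.8, within 4 to 5.8.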

Compound 4, negative logarithm of the half-maximal effective concentration: 6.21
For compound 4 the middle estimate is 1.41 log units below the measured one; the whole stated range lies below it.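

In this assay, putting bromo in place of trifluoromethyl at this position of the shared core gives a number at least 2.21 log units higher from compound 2 to compound 4 (beyond the scatter). This single change is enough to separate a compound with a measurable potency from one without. The true size of the step remains unknown because compound 2 has only a limit, not a number: the limit of < 4 in this assay, at which 2 of the 4 values shown sit.

Going by these compounds, how a nitrile or an amine at this position would compare remains open. So does whether bromo is unusually favourable here or trifluoromethyl unusually poor.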